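Amide aryl swap: indole to cyanophenyl on the shared core

The compounds below may be only part of what the source reports. "The series", "measured", "known", "first", "only" and "open" are said of these compounds alone.

Two amides of the shared core have been measured in an assay on DAN-G cells for inhibition of Indoleamine 2,3-dioxygenase 1 (Homo sapiens), read by HPLC, with a stated time of 48 h; a lower number here means a stronger inhibitor, a higher number a weaker inhibitor. Compound 1 `O=C(NCc1cccc(Cn2cnc3ccccc32)c1)c1cc(Br)c[nH]1` gives 605 nM, and compound 2 `O=C(NCc1cccc(Cn2cnc3ccccc32)c1)c1cc2ccccc2[nH]1` gives 140 nM. Compound 2 stands at the lower of the two numbers; the step of a 4.3-fold lower number from compound 1 to compound 2 (0.64 log units; beyond the scatter) is the only one recorded and is beyond the scatter.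

Compound 3 `N#Cc1ccc(C(=O)NCc2cccc(Cn3cnc4ccccc43)c2)cc1` has not been measured. It differs from compound 2 by 4-cyanophenyl in place of 1H-indol-2-yl on a carbonyl carbon: the group that leaves carries one hydrogen-bond donor and two fused aromatic rings, the group that enters carries none and a single ring with a nitrile.

Going by the values given here, no measured step covers this change directly. Among the compounds with values here, the single step of a 4.3-fold lower number from compound 1 to compound 2 (0.64 log units; beyond the scatter) shows only that the aryl group on the carbonyl moves the number in this assay by a modest amount when the five-membered ring is exchanged. Since compound 3 loses the indole that went with the lower number of compound 2, a step back toward the number of compound 1, or somewhat beyond it, is expected rather than an improvement. The expected change is a 3.6-fold higher number from compound 2 to compound 3 (0.55 log units; beyond the scatter). Compound 3 is therefore estimated at 500 nM, with a range of 150 nM to 1800 nM.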

Compound 3, half-maximal inhibitory concentration: 1940 nM
For compound 3 the middle estimate is 3.9-fold (0.59 log units) below the measured one; measured number above the stated range.
By their numbers in this assay, from the lowest: compound 2; then compound 1; then compound 3.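

In this assay, moving from 1H-indol-2-yl to 4-cyanophenyl on the carbonyl carbon gives a large loss (a 14-fold higher number from compound 2 to compound 3 (1.14 log units; beyond the scatter)), a wider step than the only one available earlier at this position (a 4.3-fold lower number from compound 1 to compound 2 (0.64 log units; beyond the scatter)). The 4-cyanophenyl amide also falls behind the 4-bromo-1H-pyrrol-2-yl amide (a 3.2-fold higher number from compound 1 to compound 3 (0.51 log units; beyond the scatter)), so the three amides separate into a clear order beyond the scatter, with compound 2 lowest, compound 1 in the middle and compound 3 highest, and this position tolerates the exchange of aryl groups less evenly than the first pair suggested. No measurement on these compounds accounts for that order.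

The step from compound 2 to compound 3 removes the hydrogen-bond donor and the second aromatic ring and adds the nitrile in a single change, so the share of each in the loss remains unresolved. A plain phenyl, a 4-bromophenyl, or a 1H-pyrrol-2-yl without the bromine on the same carbonyl would be the kind of group that separates these contributions, and the compounds shown do not include any of them.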